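Aryl ether variation in the oxime series: trifluoromethoxy analogue

This account rests on a few compounds, and the source may have more. Where it says the series, first, only, none or still open, it means among the compounds named here.

The series shares the core of compound 1 `Cc1nnsc1CO/N=C/c1c(C)nn(C)c1Oc1ccccc1Cl`, with the aryl ether as the varied part. In a functional assay on SGC-7901 cells (Homo sapiens) for inhibition, read by MTT assay, with a stated time of 48 h (on this read-out lower numbers stand for stronger inhibition and higher numbers for weaker inhibition), compound 1 gives only a limit of the assay, > 50000 nM. Compound 2 `Cc1nnsc1CO/N=C/c1c(C)nn(C)c1Oc1ccc(F)cc1` carries 4-fluorophenyl in place of 2-chlorophenyl on the ether oxygen. In this assay compound 2 likewise gives only a limit, > 50000 nM. The step that the two limits leave unreadable from compound 1 to compound 2 therefore cannot be read in size or direction, and both measured values sit at the limit of > 50000 nM in this assay, at which 2 of the 2 values shown sit.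

Compound 3 `Cc1nnsc1CO/N=C/c1c(C)nn(C)c1Oc1ccccc1OC(F)(F)F` differs from compound 1 by trifluoromethoxy in place of chloro on an aromatic carbon. Going by the values given here, no measured step bears usefully on this change: the single measured step is unreadable, so the step to compound 3 has no measured precedent for its size. With both measured values at the same limit, the expectation is that compound 3 stays near that limit, estimated as a number no higher from compound 1 to compound 3 (the limit leaves the size open). Compound 3 is expected at 50000 nM, within 15000 nM to 200000 nM, and most likely reported again as a limit rather than a number.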

Compound 3, half-maximal inhibitory concentration: > 50000 nM
Compound 3 gave a limit, no number; the forecaster's own chance of this, stated with the estimate: 75%; the middle value lies on the limit itself.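

In this assay compound 3 gives only a limit of the assay, > 50000 nM, so the change from compound 1 to compound 3 yields no readable step in size or direction. The compounds shown leave open whether any aryl ether on the shared core reaches a measurable value in this assay, and how much each aryl change matters: the limit of > 50000 nM in this assay, at which 3 of the 3 values shown sit.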